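Exchanging the dihydroxypropyl arm for a piperidinyl chain

This account rests on a few compounds, and the source may have more. Where it says the series, first, only, none or still open, it means among the compounds named here.

Within the data shown here, in a functional assay on A549 cells (Homo sapiens) for cytotoxicity, read by MTT assay, with a stated time of 72 h (a lower number here means a stronger inhibitor, a higher number a weaker inhibitor), compound 1 `O=C1c2c[n+]([O-])c3ccccc3c2C(=O)c2c1c1ccccc1n2Cc1cn(C[C@H](O)CO)nn1` gives 1030 nM and stands highest of the three numbers so far, with compound 2 `CC1(C)OCC(Cn2cc(Cn3c4c(c5ccccc53)C(=O)c3c[n+]([O-])c5ccccc5c3C4=O)nn2)O1` at 80 nM and compound 3 `CC1(C)OC[C@H](Cn2cc(Cn3c4c(c5ccccc53)C(=O)c3c[n+]([O-])c5ccccc5c3C4=O)nn2)O1` at 340 nM in the same read-out. Compound 4 `O=C1c2c[n+]([O-])c3ccccc3c2C(=O)c2c1c1ccccc1n2CCCCN1CCCCC1` keeps the core of compound 1 and differs on a saturated chain carbon bound to an aromatic nitrogen (3-(piperidin-1-yl)propyl in place of 1-(2,3-dihydroxypropyl)-1H-1,2,3-triazol-4-yl on a saturated chain carbon bound to an aromatic nitrogen), where 3-(piperidin-1-yl)propyl takes the place of 1-(2,3-dihydroxypropyl)-1H-1,2,3-triazol-4-yl. Among the measured compounds shown here, no measured step makes this exchange directly. For the measured compounds named here, two steps bear on it indirectly: each replaces the 1,2-dihydroxyethyl end with 2,2-dimethyl-1,3-dioxolan-4-yl, one large in size and one modest. Compound 4 loses that end too, so a 13-fold lower number from compound 1 to compound 2 (1.11 log units; beyond the scatter) and a 3.0-fold lower number from compound 1 to compound 3 (0.48 log units; beyond the scatter) both point towards a lower number for it, though only loosely, as the whole triazolyl group leaves as well. How far such a step reaches is also uncertain, given a 4.3-fold higher number from compound 2 to compound 3 (0.63 log units; beyond the scatter) and the fact that one of compounds 2 and 3 is drawn with a defined configuration and the other without, at the place where they differ that goes with that gap. In this assay the expected step is a 3.4-fold lower number from compound 1 to compound 4 (0.54 log units; beyond the scatter) and it is a modest one towards a lower number. The value expected for compound 4 is 300 nM with a range from 60 nM to 1500 nM by this estimate.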

Compound 4, half-maximal inhibitory concentration: 150 nM
Compound 4: middle estimate off by 2.0-fold (0.30 log units), on the high side, and the stated range covers the measured number.
By their numbers in this assay, from the lowest: compounds 2 and 4 (each within the scatter of the next); then compound 3; then compound 1.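

In this assay, the step to the piperidinyl chain is a 6.9-fold lower number from compound 1 to compound 4 (0.84 log units; beyond the scatter), so the position on a saturated chain carbon bound to an aromatic nitrogen does not depend on keeping the 1-(2,3-dihydroxypropyl)-1H-1,2,3-triazol-4-yl group. Compounds 1, 2 and 3 all keep the triazole and vary only its far end, whereas compound 4 shows that the whole group can give way to 3-(piperidin-1-yl)propyl, which has no five-membered aromatic ring, no hydrogen-bond donors and no defined stereocentre, and the number still falls. Nothing given here explains this step, as the only structural observation available concerns a different pair and a stereo element that compound 4 does not have.

Among these compounds, the single exchange leaves open how much of the step comes from the loss of the triazole and diol and how much from the entry of the piperidine. Also open, from the compounds shown here alone, is whether a morpholine ring or a dimethylamino group at the end of the same chain, or a piperidine on a shorter or longer chain, would give a similar number.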